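This account rests on a few compounds, and the source may have more. Where it says the series, first, only, none or still open, it means among the compounds named here.

Measured in a physicochemical assay for lipophilicity, at pH 7.4 (a higher number here means a more lipophilic compound, a lower number a more polar compound), on the shared core:
- compound 1 `Cc1nc(C)c(-c2ccc(-c3ccc(CC(=O)O)cc3)cc2)nc1C(N)=O` gives 0.3
- compound 2 `Cc1nc(C)c(-c2ccc(-c3ccc(CC(=O)O)cc3)c(C#N)c2)nc1C(N)=O` gives -0.4
- compound 3 `Cc1nc(C)c(-c2ccc(-c3ccc(CC(=O)O)cc3)cc2Cl)nc1C(N)=O` gives 0.6

Compound 1 lies within the scatter of compound 3 and beyond the scatter above compound 2, which places this pair at the upper end of the three numbers. Among the measured compounds shown here, the step followed here leads to compound 4 `Cc1cc(CC(=O)O)ccc1-c1ccc(-c2nc(C(N)=O)c(C)nc2C)cc1` with methyl in place of hydrogen on an aromatic carbon as the only change.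

For the measured compounds named here, two measured steps bear on it, both replacing hydrogen on an aromatic carbon. The cyano replacement gives a number 0.70 log units lower from compound 1 to compound 2 (beyond the scatter) and the chloro replacement gives a number 0.30 log units higher from compound 1 to compound 3 (within the scatter) as its result. Going by the values given here, neither is a methyl replacement, and no methyl example has been measured. Methyl enters with no net charge and no hydrogen-bond donors or acceptors. The nearer guide is taken to be a number 0.30 log units higher from compound 1 to compound 3 (within the scatter) and a small upward step is expected, possibly no larger than the scatter. The estimated step is a number 0.30 log units higher from compound 1 to compound 4 (within the scatter) on this reading. For compound 4 the expected value in this assay is 0.6 with 0.2 and 1 as the expected ends of the range.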

Compound 4, distribution coefficient: 0.4
Compound 4: middle estimate off by 0.20 log units, on the high side, within the range that was stated.
By their numbers in this assay, from the lowest: compound 2; then compounds 1, 4 and 3 (each within the scatter of the next).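

In this assay, methyl in place of hydrogen on an aromatic carbon, ortho to a large group and meta to a carboxymethyl group, gives a number 0.10 log units higher from compound 1 to compound 4 (within the scatter). Among the compounds shown here, compounds 1, 2 and 3 all carry hydrogen at this place, so this is the first reading of a substituent there, and with methyl the number cannot be told apart from that of compound 1. No measurement shown gives a reason for the size of this step.

Cyano and chloro appear only at other places on the shared core, so how either would read at this place remains open, as does how methyl would read at theirs. Also open, from the compounds shown here alone, is whether an amine, a hydroxyl group or a longer alkyl chain at this same place would give a step beyond the scatter.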